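The source may hold more compounds than are shown below. What is called first, only, known or untested is meant among the compounds shown, and "the series" means these compounds.

In an ADME assay on microsomes from liver (Mus musculus) for metabolic stability, read by LC-MS, using NADPH, with stated times of 10 min and 30 min, tested at 1 uM (on this read-out higher numbers stand for fast clearance and lower numbers for slow clearance), compound 3 `COC(=O)C1=C(CN2CCCS2(=O)=O)NC(c2nccs2)=NC1(C)c1ccc(F)cc1` gives 79 mL/min/kg, within the scatter of compound 1 `COC(=O)C1=C(CN2CCCCC2)NC(c2nccs2)=NC1(C)c1ccc(F)cc1` at 88 mL/min/kg, while compound 2 `COC(=O)C1=C(CN2CCNCC2)NC(c2nccs2)=NC1(C)c1ccc(F)cc1`, at 39 mL/min/kg, lies lower. Compound 4 `COC(=O)C1=C(Cn2ccnc2)NC(c2nccs2)=NC1(C)c1ccc(F)cc1` carries a group of 5 heavy atoms (3 carbon, 2 nitrogen; one five-membered aromatic ring with 2 hetero atoms) in place of a group of 7 heavy atoms (3 carbon, 1 nitrogen, 2 oxygen, 1 sulfur; one five-membered non-aromatic ring with 2 hetero atoms), on a saturated chain carbon bound to a double-bonded ring carbon, the entering group being 1H-imidazol-1-yl. Among the measured compounds shown here, no measured step places an aromatic ring here, so the evidence is indirect. Exchanges at this same place gave a 1.1-fold lower number from compound 1 to compound 3 (0.05 log units; within the scatter), a 2.3-fold lower number from compound 1 to compound 2 (0.35 log units; beyond the scatter) and a 2.0-fold higher number from compound 2 to compound 3 (0.31 log units; beyond the scatter), the latter two only modest. On that basis, no change beyond the scatter is expected in this assay, and the expected 1.2-fold lower number from compound 3 to compound 4 (0.08 log units; within the scatter) is correspondingly small. For compound 4 the estimate is 65 mL/min/kg, with an expected range from 35 mL/min/kg to 110 mL/min/kg.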

Compound 4, clearance: 69 mL/min/kg
Estimate against measurement, compound 4: 1.1-fold (0.03 log units) below, within the range that was stated.
By their numbers in this assay, from the lowest: compounds 2, 4, 3 and 1 (each within the scatter of the next, the first and the last beyond it).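

In this assay, 1H-imidazol-1-yl, the first aromatic ring shown on this saturated chain carbon, stays within the scatter of all three earlier groups (a 1.1-fold lower number from compound 3 to compound 4 (0.06 log units; within the scatter)) (a 1.3-fold lower number from compound 1 to compound 4 (0.11 log units; within the scatter)) (a 1.8-fold higher number from compound 2 to compound 4 (0.25 log units; within the scatter)). Compound 4 therefore sorts with neither compound 2 nor the pair of compound 1 and compound 3, although steps beyond the scatter separate that pair from compound 2. Nothing measured here accounts for this. Still open, on these data alone, is whether phenyl or 1H-pyrazol-1-yl at this place would read like 1H-imidazol-1-yl, and whether an open-chain amine such as dimethylamino would fall nearer piperazin-1-yl or piperidin-1-yl.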